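A few compounds are considered here, and "the series" means these few. Any claim that something is new, unique, unknown or untested is made for them only; others in the source may bear on it.

Compound 1 `Cc1cc(=O)n(-c2cccc(F)c2)nc1C(=O)Nc1ccc(Oc2ncnc3[nH]ccc23)cc1` is tested in a functional assay on MCF7 cells (Homo sapiens) for cytotoxicity, read by MTT assay, with a stated time of 72 h (on this read-out lower numbers stand for stronger inhibition and higher numbers for weaker inhibition), where compound 1 gives 9670 nM. Among the three compounds measured this is the highest number, so compound 1 is the weakest of the set. Compound 2 `Cc1ccc(-n2nc(C(=O)Nc3ccc(Oc4ncnc5[nH]ccc45)cc3)c(C)cc2=O)cc1` gives 3620 nM in this assay, and compound 3 `Cc1cc(=O)n(-c2ccc(Br)cc2F)nc1C(=O)Nc1ccc(Oc2ncnc3[nH]ccc23)cc1` gives 3210 nM. The two measured changes, a 2.7-fold lower number from compound 1 to compound 2 (0.43 log units; beyond the scatter) and a 3.0-fold lower number from compound 1 to compound 3 (0.48 log units; beyond the scatter), both alter the aromatic ring attached to the nitrogen of the shared core, while a 1.1-fold lower number from compound 2 to compound 3 (0.05 log units; within the scatter) shows that these two rings do not differ from each other beyond the scatter.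

Compound 4 `Cc1cc(=O)n(-c2cccc(F)c2)nc1C(=O)Nc1ccc(Oc2ncnc3c2ccn3C)cc1` differs from compound 1 in a different part of the molecule: methyl in place of hydrogen on an aromatic nitrogen. Within the data shown here, none of the measured steps touches this aromatic nitrogen, so nothing in the data tells how this assay responds to a methyl at that position. Without a bearing step, the plainest expectation is a step of no more than the scatter, in either direction, and the estimate for compound 4 stays close to compound 1, with a wide range to reflect the lack of guidance. The expected step from compound 1 is a 1.1-fold higher number from compound 1 to compound 4 (0.06 log units; within the scatter), and compound 4 is estimated at 11000 nM, with a range from 4000 nM to 40000 nM.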

Compound 4, half-maximal inhibitory concentration: 30800 nM
Compound 4: middle estimate off by 2.8-fold (0.45 log units), on the low side; measured number inside the range.
By their numbers in this assay, from the lowest: compounds 3 and 2 (each within the scatter of the next); then compound 1; then compound 4.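

Among these compounds, until now, every measured step lay on the aromatic ring attached to the nitrogen of the shared core, so this is the first reading at the aromatic nitrogen of the five-membered aromatic ring. In this assay, methyl in place of hydrogen there gives a 3.2-fold higher number from compound 1 to compound 4 (0.50 log units; beyond the scatter), a modest step towards weaker inhibition but one beyond the usual scatter, which shows that this position is not indifferent to even a small change on the core of compound 1. Nothing measured here gives a reason for this step.

The compounds shown leave open whether the loss belongs to methyl in particular or would also appear with another group on that nitrogen, such as an ethyl group, a longer chain ending in an amine, or a chain ending in a carboxylic acid. They also leave open whether methyl at this nitrogen would give a step of similar size with the 4-methylphenyl ring of compound 2 or the 4-bromo-2-fluorophenyl ring of compound 3 in place of the 3-fluorophenyl ring.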